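Working notes: from compound 3 to compound 4

The compounds below may be only part of what the source reports. "The series", "measured", "known", "first", "only" and "open" are said of these compounds alone.

Measured so far:
compound 1, `CC(=O)OCc1ccc2oc(=O)c(C(=O)Oc3cccc(Cl)c3)cc2c1`: 6.17%
compound 2, `CC(=O)OCc1ccc2oc(=O)c(C(=O)Nc3cccc(Cl)c3)cc2c1`: 42.8%
compound 3, `CCCC(=O)OCc1ccc2oc(=O)c(C(=O)Oc3cccc(Br)c3)cc2c1`: 24.7%

All three were tested in a functional assay on HT-1080 cells (Homo sapiens), read by transwell migration, with a stated time of 24 h, tested at 10 uM; on this read-out lower numbers stand for a stronger effect and higher numbers for a weaker effect at the one concentration tested. Compound 3 holds the second highest number of the three; compound 2 sits higher by a margin beyond the scatter, and compound 1 sits lower by a margin beyond the scatter. Compound 4 `NCc1ccc2oc(=O)c(C(=O)Oc3cccc(Br)c3)cc2c1` has not yet been measured. It differs from compound 3 in one place: amino in place of (propylcarbonyl)oxy on a saturated chain carbon bound to an aromatic carbon.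

Within the data shown here, the one measured step, a number 36.6 percentage points higher from compound 1 to compound 2 (beyond the scatter), concerns the group on the carbonyl carbon, not the saturated chain carbon bound to an aromatic carbon, so it does not bear on the present change. Among the measured compounds shown here, no measured pair shows what replacing (propylcarbonyl)oxy by amino does. The expectation therefore rests on compound 3 alone and carries a wide range in both directions. Compound 4 is estimated at 28% in this assay, with a range from 8% to 60%. The step this estimate implies, a number 3.3 percentage points higher from compound 3 to compound 4 (within the scatter), is expected to stay within the scatter.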

Compound 4, a percentage reported as activity, at one concentration (the size of the read-out at that concentration, not a potency): 63.6%
Compound 4: the middle estimate sits 35.6 percentage points below what was measured; measured number outside the range, above it.
By their numbers in this assay, from the lowest: compound 1; then compound 3; then compound 2; then compound 4.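

In this assay, the saturated chain carbon bound to an aromatic carbon turns out to be a position that matters: amino in place of (propylcarbonyl)oxy gives a number 38.9 percentage points higher from compound 3 to compound 4 (beyond the scatter), a clear weakening of the effect at the one concentration tested. Among these compounds, this is the first measured step at this position, so the series now has large steps at two separate sites, this carbon and the carbonyl carbon. No measurement on hand accounts for this step, and it cannot be divided between losing the ester and gaining the amine.

Open, on these data alone, is whether a hydroxyl, an acetamide or a dimethylamino group on this carbon would stay near compound 3 or fall near compound 4. Also open, as far as these compounds go, is whether the step would hold with an amide in place of the ester on the carbonyl carbon.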